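Swapping a Triazole Tail for a Chlorophenoxy Chain

The source may report more compounds than this note shows. Statements on the series, on what has been measured and on what is new or still open speak of the compounds shown alone.

Among the measured compounds shown here, compound 2, `O=C(OCC1CCCN(CCCn2cc(-c3ccccc3)nn2)C1)c1ccccc1-c1ccccc1`, gives 389000 nM in an in vitro functional assay on HEK ts201 cells for antagonist activity at Neuronal acetylcholine receptor; alpha3/beta4 (Homo sapiens), read by fluorescence and calcium flux (a higher number here means a weaker inhibitor, a lower number a stronger inhibitor), the higher of the two numbers measured so far, while compound 1, `[N-]=[N+]=NCCCN1CCCC(COC(=O)c2ccccc2-c2ccccc2)C1`, gives 1820 nM. For the measured compounds named here, the only measured step, a 210-fold higher number from compound 1 to compound 2 (2.33 log units; beyond the scatter), shows how much the group at that position can move the number. Compound 3, `O=C(OCC1CCCN(CCCCCOc2ccc(Cl)cc2)C1)c1ccccc1-c1ccccc1`, carries 2-(4-chlorophenoxy)ethyl in place of 4-phenyl-1H-1,2,3-triazol-1-yl on a saturated chain carbon, three bonds along the chain from an amine nitrogen in a ring. Going by the values given here, no measured step covers this particular exchange, so the expectation rests only on how far compound 2 had fallen. Compound 3 is expected to recover part of that loss, an estimated step of a 19-fold lower number from compound 2 to compound 3 (1.29 log units; beyond the scatter), giving an estimated 20000 nM with a range from 2000 nM to 200000 nM.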

Compound 3, half-maximal inhibitory concentration: 15500 nM
Estimate against measurement, compound 3: 1.3-fold (0.11 log units) above; the measured number falls inside the stated range.
By their numbers in this assay, from the lowest: compound 1; then compound 3; then compound 2.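

Replacing 4-phenyl-1H-1,2,3-triazol-1-yl with 2-(4-chlorophenoxy)ethyl brings a 25-fold lower number from compound 2 to compound 3 (1.40 log units; beyond the scatter) in this assay, so a large group at this position need not cost as much as the triazole did, even though both groups carry a six-membered aromatic ring of carbon only. The much smaller azido group still keeps the lead, with an 8.5-fold higher number from compound 1 to compound 3 (0.93 log units; beyond the scatter). No measurement here explains these differences.

From the compounds shown here alone, it remains open how a phenoxy group without the chlorine would compare. An amine or a carboxylic acid at the end of the chain is also untested among the compounds shown.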